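Swapping a Hydroxy for an Ethyl on the Sulfonamide Tail

A few compounds are considered here, and "the series" means these few. Any claim that something is new, unique, unknown or untested is made for them only; others in the source may bear on it.

Measured compounds:
compound 1 `CC[C@@H]1C(=O)N(C)c2cnc(Nc3ccc(S(=O)(=O)NCCO)cc3)nc2N1C1CCCC1` — 563 nM
compound 2 `CCC1C(=O)N(C)c2cnc(-n3ccc4cc(C(=O)NCC(C)C)ccc43)nc2N1c1ccn(C)n1` — 19200 nM

In a functional assay on A549 cells (Homo sapiens) for antiproliferative activity, read by CCK-8 assay, with a stated time of 72 h (a higher number here means a weaker inhibitor of growth, a lower number a stronger inhibitor of growth), compound 1 gives 563 nM, the lowest of the two numbers shown, while compound 2 gives 19200 nM, a gap well beyond the scatter. Compound 3 `CCCCNS(=O)(=O)c1ccc(Nc2ncc3c(n2)N(C2CCCC2)[C@H](CC)C(=O)N3C)cc1` differs from compound 1 in one place: ethyl in place of hydroxy on a saturated chain carbon, two bonds along the chain from a sulfonamide nitrogen. Within the data shown here, no measured pair shows this same change, so its direction is open. The expected step from compound 1 to compound 3 is a 1.2-fold higher number from compound 1 to compound 3 (0.06 log units; within the scatter), likely within the scatter. Compound 3 is therefore estimated at 650 nM, with a range from 200 nM to 2200 nM.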

Compound 3, concentration for 50% growth inhibition: 477 nM
Beside the measured number, compound 3's estimate is 1.4-fold (0.13 log units) above it, and the stated range covers the measured number.
By their numbers in this assay, from the lowest: compounds 3 and 1 (each within the scatter of the next); then compound 2.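

In this assay, ethyl in place of hydroxy at this position on the sulfonamide tail gives a 1.2-fold lower number from compound 1 to compound 3 (0.07 log units; within the scatter) and so leaves the two compounds indistinguishable. The 2-hydroxyethyl tail of compound 1 can therefore be replaced by the butyl tail of compound 3, which counts no hydrogen-bond donor or acceptor in the entering ethyl, with growth inhibition staying within the scatter. No supporting measurement accounts for this result. From the compounds shown here alone, whether an amine or a carboxylic acid at the end of this chain, or a longer chain, would read the same remains open.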